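This account rests on a few compounds, and the source may have more. Where it says the series, first, only, none or still open, it means among the compounds named here.

Measured compounds:
- Compound 1 `CC(C)C(/C=C1\NC(=O)NC1=O)c1ccc(-c2ccc3cccc(F)c3c2)[nH]c1=O`: in a functional assay on CHO cells for antagonist activity at prostaglandin E2 receptor EP3 subtype (Homo sapiens), read by cAMP accumulation, with a stated time of 30 min (on this read-out lower numbers stand for stronger inhibition and higher numbers for weaker inhibition), compound 1 gives 87 nM
- Compound 2 `CC(C)C(/C=C1\SC(=O)NC1=O)c1ccc(-c2ccc3cccc(F)c3c2)[nH]c1=O`: in this assay compound 2 gives 27 nM

Compound 2 holds the lowest of the two numbers in this assay; its nearest neighbour is compound 1, and the step of a 3.2-fold lower number from compound 1 to compound 2 (0.51 log units; beyond the scatter) lies beyond the scatter.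

The unmeasured compound 3 `CC(C)C(/C=C1/C(=O)NC(=O)N1C)c1ccc(-c2ccc3cccc(F)c3c2)[nH]c1=O` differs from compound 2 in one place: a group of 9 heavy atoms (5 carbon, 2 nitrogen, 2 oxygen; one five-membered non-aromatic ring with 2 hetero atoms) in place of a group of 8 heavy atoms (4 carbon, 1 nitrogen, 2 oxygen, 1 sulfur; one five-membered non-aromatic ring with 2 hetero atoms), on a saturated chain carbon bound to an aromatic carbon and a saturated chain carbon. Going by the values given here, only one measured step bears on this change, namely a 3.2-fold lower number from compound 1 to compound 2 (0.51 log units; beyond the scatter), in which the ring entering compound 2 lowered the number modestly relative to the ring of compound 1. Compound 3 takes the ring of compound 2 away again and puts in its place a ring that, on the counts given, resembles the ring of compound 1 more than that of compound 2, carrying one more carbon and one less acceptor. A modest rise in this assay from compound 2 is therefore expected, of about the size seen between compound 1 and compound 2, with the step of a 4.1-fold higher number from compound 2 to compound 3 (0.61 log units; beyond the scatter) as the estimate. For compound 3 the expected value in this assay is 110 nM, within a range of 35 nM to 350 nM.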

Compound 3, half-maximal inhibitory concentration: 11 nM
Estimate against measurement, compound 3: 10-fold (1.00 log units) above; measured number outside the range, below it.
By their numbers in this assay, from the lowest: compound 3; then compound 2; then compound 1.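

In this assay, putting methyl in place of hydrogen on an amide-type nitrogen in a ring gives a 7.9-fold lower number from compound 1 to compound 3 (0.90 log units; beyond the scatter), so this single small change to the ring of compound 1 reaches further than the swap of rings seen earlier, a 3.2-fold lower number from compound 1 to compound 2 (0.51 log units; beyond the scatter). The sulfur-containing ring therefore does not mark the low end at this saturated chain carbon, as the earlier pair alone might have suggested: the methylated ring without sulfur goes lower still, with a 2.5-fold lower number from compound 2 to compound 3 (0.39 log units; beyond the scatter), and both steps lie beyond the usual scatter. Nothing supplied here accounts for why the methyl group lowers the number.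

The three compounds leave open whether the trend continues with an ethyl group or a longer chain on that amide-type nitrogen, or whether a polar group such as a hydroxyethyl or a carboxylic acid chain would be accepted there. They also leave open whether methyl on the amide-type nitrogen of the sulfur-containing ring of compound 2 would lower the number in the same way, since the effect of the methyl group is seen on one ring only.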